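The source may hold more compounds than are shown below. What is called first, only, known or untested is meant among the compounds shown, and "the series" means these compounds.

Measured in a functional assay on Bel-7402 cells (Homo sapiens) for cytotoxicity, read by MTT assay, with a stated time of 72 h; on this read-out lower numbers stand for stronger inhibition and higher numbers for weaker inhibition:
compound 1 `O=C(Nc1ccc(-n2ncc3c(C(F)(F)F)cccc32)cc1)Nc1ccc(Cl)c(C(F)(F)F)c1` gives 16000 nM
compound 2 `Cc1cccc2c1cnn2-c1ccc(NC(=O)Nc2ccc(Cl)c(C(F)(F)F)c2)cc1` gives 6700 nM
compound 3 `CNc1cccc2c1cnn2-c1ccc(NC(=O)Nc2ccc(Cl)c(C(F)(F)F)c2)cc1` gives 5000 nM

Compound 2 holds the second highest of the three numbers; compound 3 is nearest, the step of a 1.3-fold lower number from compound 2 to compound 3 (0.13 log units; within the scatter) lying within the scatter, and compound 1 is furthest, as a 2.4-fold lower number from compound 1 to compound 2 (0.38 log units; beyond the scatter) shows. Compound 4 `O=C(Nc1ccc(-n2ncc3ccncc32)cc1)Nc1ccc(Cl)c(C(F)(F)F)c1` is not yet measured. Its change from compound 2 is a group of 9 heavy atoms (6 carbon, 3 nitrogen; one five-membered aromatic ring with 2 hetero atoms, one six-membered aromatic ring with 1 hetero atom) in place of a group of 10 heavy atoms (8 carbon, 2 nitrogen; one five-membered aromatic ring with 2 hetero atoms, one six-membered aromatic ring of carbon only), on an aromatic carbon. The measured steps all concern the group carried on the six-membered aromatic ring of carbon only: a 2.4-fold lower number from compound 1 to compound 2 (0.38 log units; beyond the scatter), a 3.2-fold lower number from compound 1 to compound 3 (0.51 log units; beyond the scatter) and a 1.3-fold lower number from compound 2 to compound 3 (0.13 log units; within the scatter). None exchanges one fused ring system for another, so they bear only loosely on this step. The expected step in this assay is therefore modest, a 1.2-fold higher number from compound 2 to compound 4 (0.08 log units; within the scatter), with no firm direction. Compound 4 is estimated at 8000 nM, range 3000 nM to 20000 nM.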

Compound 4, half-maximal inhibitory concentration: 4000 nM
Beside the measured number, compound 4's estimate is 2.0-fold (0.30 log units) above it; low and high end bracket the measured number.
By their numbers in this assay, from the lowest: compounds 4, 3 and 2 (each within the scatter of the next); then compound 1.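

Exchanging the whole fused ring system, not only a group on it, is tolerated in this assay: the 4-methyl-1H-indazol-1-yl group gives way to a system with a six-membered aromatic ring with 1 hetero atom, with a 1.7-fold lower number from compound 2 to compound 4 (0.22 log units; within the scatter). This single step removes the methyl and adds the hetero atom, so the two contributions cannot be separated. No measurement here explains the result.

Still open, on these data alone, is how a carboxylic acid, an amine or a longer chain on the new ring system would read out in this assay.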